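Replacing the arylamino group on the shared core

This account rests on a few compounds, and the source may have more. Where it says the series, first, only, none or still open, it means among the compounds named here.

- compound 1 `Cc1ccc(NC2=CC(=O)c3c(nc4n3[C@H]3OC[C@@H](O)[C@H]3OC4)C2=O)cc1C` gives 4320 nM
- compound 2 `COc1ccccc1NC1=CC(=O)c2c(nc3n2[C@H]2OC[C@@H](O)[C@H]2OC3)C1=O` gives 7460 nM
- compound 3 `O=C1C(N2CCCCC2)=CC(=O)c2c1nc1n2[C@H]2OC[C@@H](O)[C@H]2OC1` is not yet measured

Among the compounds with values here, in a functional assay on HeLa cells (Homo sapiens) for inhibition, read by sulforhodamine B assay (on this read-out higher numbers stand for weaker inhibition and lower numbers for stronger inhibition), the only measured step is a 1.7-fold higher number from compound 1 to compound 2 (0.24 log units; within the scatter), which sets no order between the two values. Compound 2 therefore stands level with compound 1. The next change is piperidin-1-yl in place of (2-methoxyphenyl)amino on a double-bonded ring carbon. Within the data shown here, the measured step only exchanged one aryl group for another on an amine nitrogen, and no measured compound carries piperidin-1-yl. The expectation therefore starts from compound 2 at 7460 nM, with no shift beyond the scatter foreseen. The expected step is a 1.2-fold lower number from compound 2 to compound 3 (0.09 log units; within the scatter). For compound 3 the estimate is 6000 nM, with an expected range from 1500 nM to 25000 nM.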

Compound 3, half-maximal inhibitory concentration: > 16000 nM
Compound 3: only a limit was reported; the forecaster's own chance of this, stated with the estimate: 10%; at least 2.6-fold (0.42 log units) between middle value and limit.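

Compound 3 is reported only as a limit: the limit of > 16000 nM in this assay, at which 1 of the 3 values shown sits. Unlike the aryl exchange on the amine nitrogen, replacing the arylamino group on this double-bonded ring carbon with piperidin-1-yl moves the read-out in this assay beyond the scatter, giving an at least 2.1-fold higher number from compound 2 to compound 3 (0.33 log units; beyond the scatter) and an at least 3.7-fold higher number from compound 1 to compound 3 (0.56 log units; beyond the scatter). These steps set only a lower bound on the size of the change.

The compounds shown do not separate loss of the amine hydrogen from loss of the aromatic ring. A cyclohexylamino group and a methyl on the arylamine nitrogen would address these two changes separately.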